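The source may hold more compounds than are shown below. What is called first, only, known or untested is meant among the compounds shown, and "the series" means these compounds.

Measured so far:
compound 1 `O=C(NC[C@H]1CCCC[C@H]1O)NC1CCN(Cc2ccn(-c3ccc(C(F)(F)F)cc3)c2)CC1`: 63 nM
compound 2 `O=C(NC1CCN(Cc2ccn(-c3ccc(C(F)(F)F)cc3)c2)CC1)N1CC[C@@H](O)C1`: 138 nM

In an assay on HEK293 cells for displacement of a labelled ligand from melanin-concentrating hormone receptor 1 (Homo sapiens) (on this read-out lower numbers stand for stronger inhibition and higher numbers for weaker inhibition), compound 2 gives 138 nM, the higher of the two numbers recorded; compound 1 gives 63 nM. For the measured compounds named here, the one step between them, a 2.2-fold higher number from compound 1 to compound 2 (0.34 log units; beyond the scatter), is modest but beyond the usual scatter. Compound 3 `O=C(NCC1(O)CCCCC1)NC1CCN(Cc2ccn(-c3ccc(C(F)(F)F)cc3)c2)CC1` differs from compound 2 by ((1-hydroxycyclohexyl)methyl)amino in place of 3-hydroxypyrrolidin-1-yl on a carbonyl carbon. This reverses the kind of change seen in that step: a cyclic hydroxy-amine on the carbonyl carbon again gives way to an open-chain group carrying a hydroxycyclohexyl ring through a methylene. The group entering compound 3 is of a similar kind to that in compound 1, though its hydroxyl is placed differently, so the return need not be complete. Compound 3 is therefore expected to show a 1.7-fold lower number from compound 2 to compound 3 (0.24 log units; within the scatter), a modest drop back toward compound 1. The estimate for compound 3 is 80 nM, with a range of 35 nM to 180 nM.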

Compound 3, half-maximal inhibitory concentration: 44 nM
Compound 3: the middle estimate sits 1.8-fold (0.26 log units) above what was measured; the range from low to high includes it.
By their numbers in this assay, from the lowest: compounds 3 and 1 (each within the scatter of the next); then compound 2.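

In this assay, replacing 3-hydroxypyrrolidin-1-yl with ((1-hydroxycyclohexyl)methyl)amino on the carbonyl carbon gives a 3.1-fold lower number from compound 2 to compound 3 (0.50 log units; beyond the scatter), so the lower number seen with compound 1 is not confined to a single group: both groups with a hydroxycyclohexyl ring on a methylene give lower numbers than the hydroxypyrrolidine. Exchanging 2-hydroxycyclohexyl for 1-hydroxycyclohexyl gives a 1.4-fold lower number from compound 1 to compound 3 (0.16 log units; within the scatter), so this assay does not separate these two placements of the hydroxyl. No evidence is available on what lies behind these differences.

The compounds shown leave open whether the hydroxyl matters at all, which a (cyclohexylmethyl)amino group on the same carbonyl carbon would test. They also leave open whether the ring size or the open-chain amino link accounts for the gap, which a 4-hydroxypiperidin-1-yl group could help to separate.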